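A step hidden behind a limit

This account rests on a few compounds, and the source may have more. Where it says the series, first, only, none or still open, it means among the compounds named here.

Compound 1 `O=C(NCC1CCNCC1)c1ccc(C2CCC3(CC2)OOC2(OO3)C3CC4CC(C3)CC2C4)cc1`: < 4 h (a limit)
Compound 2 `NC1CN(C(=O)c2ccc(C3CCC4(CC3)OOC3(OO4)C4CC5CC(C4)CC3C5)cc2)C1`: < 4 h (a limit)

In an ADME assay on blood (Rattus norvegicus) for metabolic stability, read by LC-MS (a higher number here means that the compound lasts longer, a lower number that the compound disappears faster), compound 2 gives < 4 h, which is a limit and not a number. It therefore stands at the limit of < 4 h in this assay, at which 2 of the 2 values shown sit. Compound 3 `NC1CCN(C(=O)c2ccc(C3CCC4(CC3)OOC3(OO4)C4CC5CC(C4)CC3C5)cc2)CC1` differs from it by 4-aminopiperidin-1-yl in place of 3-aminoazetidin-1-yl on a carbonyl carbon. Among the measured compounds shown here, the only measured step bearing on this change is a step that the two limits leave unreadable from compound 1 to compound 2. It offers no size to carry over, so no step beyond the scatter is expected in either direction, and a result at the same limit is likely. The expected change is a step that the limit leaves unreadable from compound 2 to compound 3. Compound 3 is estimated at 2.5 h, with an expected range of 1 h to 5 h.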

Compound 3, half-life: < 4 h
Compound 3: only a limit was reported; the forecaster's own chance of this, stated with the estimate: 85%; the middle value is on the limit's open side.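

Among the compounds shown here, compound 1, compound 2 and compound 3 all rest on a limit in this assay, so no step among them can be read: the limit of < 4 h in this assay, at which 3 of the 3 values shown sit. The compounds shown leave open how long each one actually lasts and whether exchanging the group on the carbonyl carbon changes that at all.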